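This account rests on a few compounds, and the source may have more. Where it says the series, first, only, none or still open, it means among the compounds named here.

Measured so far:
compound 1 `Fc1cccc(F)c1C1=NC(c2ccccc2)CO1` — 3.01
compound 2 `O=[N+]([O-])c1ccccc1-c1ncco1` — 1.27
compound 3 `Cc1cccc(C2=NC(c3ccccc3)CO2)c1` — 4.11

In a physicochemical assay for lipophilicity (a higher number here means a more lipophilic compound, a lower number a more polar compound), compound 1 gives 3.01, the second highest of the three numbers. Compound 3 stands nearest, with a higher number, and the gap lies beyond the scatter; compound 2 lies furthest, with a lower number, again beyond the scatter.

Compound 4 `Fc1ccccc1C1=NC(c2ccccc2)CO1` is not yet measured in this assay. It differs from compound 1 in one place: hydrogen in place of fluoro on an aromatic carbon. One fluoro leaves and a hydrogen enters, on an aromatic carbon of the ring of carbon only.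

For the measured compounds named here, no comparable step is available among the measured compounds. A small downward step is expected from compound 1 to compound 4 in this assay, likely within the scatter, about a number 0.16 log units lower from compound 1 to compound 4 (within the scatter). Compound 4 is therefore estimated at 2.85, with a range from 2.55 to 3.15.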

Compound 4, partition coefficient: 3.51
Estimate against measurement, compound 4: 0.66 log units below; the measured number lies above the stated range.
By their numbers in this assay, from the lowest: compound 2; then compound 1; then compound 4; then compound 3.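

For the compounds shown here, this is the first single-place comparison, and it shows that the position, ortho to a large group and meta to a fluoro group, is not silent: in this assay, hydrogen in place of fluoro gives a number 0.50 log units higher from compound 1 to compound 4 (beyond the scatter). The number rises on losing a fluoro, though this rests on one pair only. Nothing at hand bears on why the number moves this way.

On these data alone, whether a methoxy group or an amine at this position would move the number in the same direction stays open. So does whether the fluoro remaining in compound 4 would give a comparable step on replacement by hydrogen.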